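The source may report more compounds than this note shows. Statements on the series, on what has been measured and on what is new or still open speak of the compounds shown alone.

Measured in a functional assay on PC-3 cells (Homo sapiens) for antiproliferative activity, read by MTT assay, with a stated time of 24 h; on this read-out lower numbers stand for stronger inhibition and higher numbers for weaker inhibition:
- compound 1 `COc1ccc(-c2noc(-c3ccncc3)n2)cc1OC1CCCC1`: > 1000000 nM
- compound 2 `COc1ccc(-c2noc(C3CCCN3)n2)cc1OC1CCCC1`: > 1000000 nM
- compound 3 `COc1ccc(-c2noc(-c3ccc(F)cc3)n2)cc1OC1CCCC1`: > 1000000 nM

All three entries are limits of the assay, not numbers: the limit of > 1000000 nM in this assay, at which 3 of the 3 values shown sit. For compound 3 the reading is > 1000000 nM, which is a limit, so it cannot be ranked against the other two.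

Compound 4 `COc1ccc(-c2noc(-c3ccc(F)cc3)n2)cc1O` keeps the 4-fluorophenyl group of compound 3 and changes another place: hydrogen in place of cyclopentyl on an oxygen on an aromatic ring. In short, cyclopentyloxy becomes hydroxy. The closest measured steps are a step that the two limits leave unreadable from compound 1 to compound 3 and a step that the two limits leave unreadable from compound 2 to compound 3. Neither has a readable size, and both alter the group on an aromatic carbon, not the cyclopentyl. Within the data shown here, no measured step touches the cyclopentyl, so the data offer neither a size nor a direction for this change. In this assay no readable step is expected, and another limit is the likeliest report.

The expected change is a number no higher from compound 3 to compound 4 (the limit leaves the size open). For compound 4 the estimate is 1000000 nM, with an expected range from 200000 nM to 3000000 nM.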

Compound 4, half-maximal inhibitory concentration: > 1000000 nM
Compound 4: a limit, no number; the forecaster's own chance of this, stated with the estimate: 70%; the middle value sits exactly at the limit.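

Compound 3 and compound 4 are both limits of the assay rather than numbers, so no size can be read for the change from cyclopentyloxy to hydroxy: the limit of > 1000000 nM in this assay, at which 4 of the 4 values shown sit.

The compounds shown leave open whether any of the four inhibits more strongly than another, and whether either change of group alters activity at all.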